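Swapping the thiophene for a furan on the lactam nitrogen

A few compounds are considered here, and "the series" means these few. Any claim that something is new, unique, unknown or untested is made for them only; others in the source may bear on it.

Compound 2 `O=C(NCc1ccc(Cl)cc1Cl)[C@@H]1CCC(=O)N1c1ccsc1` gives 813 nM in an assay on HEK293 cells for inhibition of P2X purinoceptor 7 (Homo sapiens), read by flow cytometry, with stated times of 15 min and 1 h (a higher number here means a weaker inhibitor, a lower number a stronger inhibitor), the higher of the two numbers measured, while compound 1 `O=C(NCc1ccc(Cl)cc1Cl)[C@@H]1CCC(=O)N1c1cccs1` gives 229 nM. Within the data shown here, the one measured step, a 3.6-fold higher number from compound 1 to compound 2 (0.55 log units; beyond the scatter), is the only guide. Compound 3 `O=C(NCc1ccc(Cl)cc1Cl)[C@@H]1CCC(=O)N1c1ccco1` carries the change (furan-2-yl in place of thiophen-3-yl on an amide-type nitrogen in a ring). From the compounds shown here alone, since furan-2-yl is named like thiophen-2-yl of compound 1 rather than thiophen-3-yl, a partial return is expected, though oxygen for sulfur is untested here. For compound 3 the expected step is a 2.0-fold lower number from compound 2 to compound 3 (0.31 log units; beyond the scatter), giving an estimate of 400 nM with a range from 150 nM to 1500 nM.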

Compound 3, half-maximal inhibitory concentration: 244 nM
Compound 3: the middle estimate sits 1.6-fold (0.21 log units) above what was measured; the range from low to high includes it.
By their numbers in this assay, from the lowest: compounds 1 and 3 (each within the scatter of the next); then compound 2.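

On this amide-type nitrogen in a ring, furan-2-yl gives a 3.3-fold lower number from compound 2 to compound 3 (0.52 log units; beyond the scatter), and set against thiophen-2-yl it gives a 1.1-fold higher number from compound 1 to compound 3 (0.03 log units; within the scatter). Furan-2-yl and thiophen-2-yl therefore cannot be told apart here, and among these three groups only thiophen-3-yl stands apart. Nothing measured here explains that difference.

From the compounds shown here alone, whether furan-3-yl would sit with thiophen-3-yl remains open. So does how a phenyl ring or a cyclopentyl ring would compare on this nitrogen.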